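Oxolanyl in Place of Methoxyazetidinyl on the Carbonyl

The source may hold more compounds than are shown below. What is called first, only, known or untested is meant among the compounds shown, and "the series" means these compounds.

Compound 2 `CCn1c(-c2ccc(C(F)(F)F)nc2)nc2c(O[C@H]3CCN(C(=O)N4CC(OC)C4)C3)ncnc21`: 4.2 L/kg
Compound 1 `CCn1c(-c2cnc(C)nc2)nc2c(N[C@H]3CCN(C(=O)C4CCOC4)C3)ncnc21`: 2.3 L/kg

In an ADME assay (Rattus norvegicus, strain Wistar Han) for pharmacokinetics (a lower number here means that more of the compound stays in the plasma, a higher number that more of the compound sits outside the plasma), compound 2 gives 4.2 L/kg, the top of the two numbers, while compound 1 gives 2.3 L/kg, a gap within the scatter. Compound 3 `CCn1c(-c2ccc(C(F)(F)F)nc2)nc2c(O[C@H]3CCN(C(=O)C4CCOC4)C3)ncnc21` differs from compound 2 in one place: oxolan-3-yl in place of 3-methoxyazetidin-1-yl on a carbonyl carbon. For the measured compounds named here, compound 1 carries the same oxolanyl carbonyl but differs from compound 2 elsewhere as well, so no single-change step exists for this assay. A small step is expected, a 1.2-fold lower number from compound 2 to compound 3 (0.08 log units; within the scatter), with no direction beyond the scatter. Compound 3 is expected to give 3.5 L/kg, between 2 L/kg and 6 L/kg.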

Compound 3, volume of distribution: 3.6 L/kg
Compound 3: middle estimate off by 1.0-fold (0.01 log units), on the low side; the measured number falls inside the stated range.
By their numbers in this assay, from the lowest: compounds 1, 3 and 2 (each within the scatter of the next).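

In this assay, for the compounds shown here, the first single-change step at this carbonyl carbon reads a 1.2-fold lower number from compound 2 to compound 3 (0.07 log units; within the scatter) and so lies within the scatter. Oxolan-3-yl and 3-methoxyazetidin-1-yl, a five-membered and a four-membered ring, therefore cannot be told apart at this position. Nothing at hand accounts for this result. As far as these compounds go, whether a carboxylic acid or a primary amine on this carbonyl would give a step beyond the scatter remains open. The reading also rests on a single pair, so it may not carry over to other groups on the shared core.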